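A few compounds are considered here, and "the series" means these few. Any claim that something is new, unique, unknown or untested is made for them only; others in the source may bear on it.

Three members of the shared core have numbers in a functional assay on HFF cells (Homo sapiens) for inhibition; a lower number here means a stronger inhibitor, a higher number a weaker inhibitor. Compound 1 `CSc1nc2cnsc2n1[C@H]1C[C@H](O)[C@@H](CO)O1` gives only a limit, > 100000 nM (the limit of > 100000 nM in this assay, at which 1 of the 3 values shown sits). Compound 2 `CSc1nc2snc(C)c2n1[C@H]1C[C@H](O)[C@@H](CO)O1` gives 32000 nM. Compound 3 `CSc1nc2sncc2n1[C@H]1C[C@H](O)[C@@H](CO)O1` gives 15000 nM, the lowest of the two numbers, reached by a 2.1-fold lower number from compound 2 to compound 3 (0.33 log units; beyond the scatter). On these data alone, compound 4 `OC[C@H]1O[C@@H](n2c(SCc3ccccc3)nc3sncc32)C[C@@H]1O` is untested; it differs from compound 3 by phenyl in place of hydrogen on a saturated chain carbon bound to a sulfur. Among the compounds with values here, the single recorded step, hydrogen in place of methyl on an aromatic carbon, does not involve the methylsulfanyl group, so no measured step bears on the change from methylsulfanyl to benzylsulfanyl; the only anchor is that compound 3 sits at 15000 nM. A step of about a 1.5-fold lower number from compound 3 to compound 4 (0.18 log units; within the scatter) in this assay is expected, with wide uncertainty. Compound 4 is therefore estimated at 10000 nM, within a range from 2000 nM to 50000 nM.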

Compound 4, half-maximal inhibitory concentration: 2100 nM
The estimate for compound 4 lay 4.8-fold (0.68 log units) above the measured number; the range from low to high includes it.
By their numbers in this assay, from the lowest: compound 4; then compound 3; then compound 2. At a limit, above all of these: compound 1.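

Replacing methylsulfanyl with benzylsulfanyl gives the first listed step at this position, on a saturated chain carbon bound to a sulfur: in this assay there is a 7.1-fold lower number from compound 3 to compound 4 (0.85 log units; beyond the scatter). The position therefore accepts phenyl, a six-membered aromatic ring of carbon only, and the number falls rather than rises. Nothing shown gives a cause for this step.

On these data alone, whether a longer chain in place of benzyl, or an amine on the phenyl, would lower the number further remains open. Also open, as far as these compounds go, is whether benzylsulfanyl has a similar effect on the cores of compound 1 and compound 2.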